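Side-chain variation on the glycinamide ester series

The source may report more compounds than this note shows. Statements on the series, on what has been measured and on what is new or still open speak of the compounds shown alone.

Measured so far:
Compound 1 `O=C(CN(c1nc(Cl)nc2[nH]cnc12)C1CC1)N[C@@H](CO)C(=O)OCc1ccccc1` — 27.9%
Compound 2 `CC[C@H](C)[C@H](NC(=O)CN(c1nc(Cl)nc2[nH]cnc12)C1CC1)C(=O)OCc1ccccc1` — 6.9%

In a functional assay on the whole organism (Tail, strain ICR) with Mus musculus as the target, in the tail flick test, with a stated time of 150 min, at a dose of 25 umol/kg by the oral route (a higher number here means a stronger effect of the compound at the dose given, a lower number a weaker effect), compound 2 stands lowest of the two numbers; its nearest neighbour is compound 1, and the step of a number 21 percentage points lower from compound 1 to compound 2 (beyond the scatter) lies beyond the scatter. Compound 3 `CSCC[C@H](NC(=O)CN(c1nc(Cl)nc2[nH]cnc12)C1CC1)C(=O)OCc1ccccc1` differs from compound 2 by 2-(methylsulfanyl)ethyl in place of sec-butyl on a saturated chain carbon bound to an amide-type nitrogen and a carbonyl carbon. Within the data shown here, no measured step covers this exact change; the one step known, which replaced hydroxymethyl by sec-butyl at the same place, is of a different kind, so only a small shift in this assay is expected. Compound 3 is expected to give 12% in this assay, within 0% to 30%, a step of a number 5.1 percentage points higher from compound 2 to compound 3 (within the scatter).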

Compound 3, a percentage reported as activity, at one dose (the size of the read-out at that dose, not a potency): 17.6%
Beside the measured number, compound 3's estimate is 5.6 percentage points below it; the range from low to high includes it.
By their numbers in this assay, from the lowest: compound 2; then compound 3; then compound 1.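

In this assay, the side chain at this carbon matters even with the heavy-atom count unchanged: 2-(methylsulfanyl)ethyl in place of sec-butyl gives a number 10.7 percentage points higher from compound 2 to compound 3 (beyond the scatter) at this position. The hydroxymethyl side chain of compound 1 still stands ahead, with a number 10.3 percentage points lower from compound 1 to compound 3 (beyond the scatter) in the same read-out, so compound 3 falls between the other two. No evidence here bears on what sets this order. As far as these compounds go, whether an amine, a carboxylic acid or a longer thioether chain at this carbon would exceed compound 1 remains open, as does whether the order holds at other doses or times.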